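The compounds below may be only part of what the source reports. "The series", "measured", "known", "first", "only" and "open" are said of these compounds alone.

Measured so far:
compound 1 `O=C(Nc1ccc(Oc2ccnc3[nH]ccc23)cc1)c1cc2cccnc2n(-c2ccc(Br)cc2F)c1=O`: 2360 nM
compound 2 `O=C(Nc1ccc(Oc2ccnc3[nH]ccc23)c(F)c1)c1cc2cccnc2n(-c2ccc(Cl)cc2)c1=O`: 82 nM
compound 3 `O=C(Nc1ccc(Oc2ccnc3[nH]ccc23)c(F)c1)c1cc2cccnc2n(-c2ccc(Br)cc2)c1=O`: 120 nM

In a functional assay on HT-29 cells (Homo sapiens) for antiproliferative activity, read by MTT assay, with a stated time of 72 h (on this read-out lower numbers stand for stronger inhibition and higher numbers for weaker inhibition), compound 3 gives the second highest of the three numbers. Its nearest neighbour is compound 2, and the step of a 1.5-fold higher number from compound 2 to compound 3 (0.17 log units; within the scatter) lies within the scatter. For the measured compounds named here, compound 1 is far away: compound 1 gives 2360 nM against compound 3 with 120 nM, a gap that is beyond the scatter, though the two differ in more than one place and no single step connects them.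

Compound 4 `O=C(Nc1ccc(Oc2ccnc3[nH]ccc23)c(F)c1)c1cc2cccnc2n(-c2ccc(Br)cc2F)c1=O` arises from compound 3 by fluoro in place of hydrogen on an aromatic carbon. Going by the values given here, no measured step reports this change on its own. Among the compounds with values here, the only measured step, between compound 2 and compound 3, concerns a different position and was small. Compound 1 also carries a 4-bromo-2-fluorophenyl group and gives the weakest number, which is taken as a cautious hint of loss, without a clean comparison. Compound 4 is therefore expected to lose some potency, with a 2.5-fold higher number from compound 3 to compound 4 (0.40 log units; beyond the scatter), and its estimated value is 300 nM with a range of 100 nM to 1200 nM.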

Compound 4, half-maximal inhibitory concentration: 820 nM
Beside the measured number, compound 4's estimate is 2.7-fold (0.44 log units) below it, and the stated range covers the measured number.
By their numbers in this assay, from the lowest: compounds 2 and 3 (each within the scatter of the next); then compound 4; then compound 1.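

In this assay, the change from 4-bromophenyl to 4-bromo-2-fluorophenyl gives a 6.8-fold higher number from compound 3 to compound 4 (0.83 log units; beyond the scatter), so this place on the ring responds clearly to a single added fluoro, unlike the bromo for chloro swap, which stayed within the scatter. The group change as a whole gives a 10-fold higher number from compound 2 to compound 4 (1.00 log units; beyond the scatter), and the loss goes with the added fluoro rather than with the halogen swap. Fluoro elsewhere in the molecule acts in the opposite direction, with both compounds carrying 4-bromo-2-fluorophenyl: a 2.9-fold lower number from compound 1 to compound 4 (0.46 log units; beyond the scatter), so the effect of adding fluoro depends on where it sits in these compounds.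

No measurement given here explains the loss. Whether it is particular to fluoro stays open: the compounds shown do not tell how a methyl or a methoxy group at this same place would read.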